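Thiazole-linked acylhydrazone series: trifluoromethyl addition on the hydrazone ring

The compounds below may be only part of what the source reports. "The series", "measured", "known", "first", "only" and "open" are said of these compounds alone.

Measured compounds:
compound 1, `Cc1nc(N(C)C(=O)NC(=O)c2c(F)cccc2F)sc1C(=O)N/N=C/c1cccc(C(F)(F)F)c1`, 26.8 ug/mL
compound 2, `CN(C(=O)NC(=O)c1ccc(C(F)(F)F)cc1)c1nc(C(F)(F)F)c(C(=O)N/N=C/c2cccc(C(F)(F)F)c2)s1`, 6.2 ug/mL
compound 3, `CN(C(=O)NC(=O)c1ccc(C(F)(F)F)cc1)c1nc(C(F)(F)F)c(C(=O)N/N=C/c2cc(C(F)(F)F)cc(C(F)(F)F)c2)s1`, 5.78 ug/mL

All three were run in a functional assay on HeLa cells (Homo sapiens) for inhibition, read by MTT assay, with a stated time of 72 h; on this read-out lower numbers stand for stronger inhibition and higher numbers for weaker inhibition. Compound 1 gives the highest number of the three; compound 2 gives the nearest lower number, and compound 3 the furthest, both gaps lying beyond the scatter. How the core of compound 1 differs from the core of compound 2 is not broken down here.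

Between compound 2 and compound 3 one change is made: trifluoromethyl in place of hydrogen on an aromatic carbon. The step it produced in this assay is a 1.1-fold lower number from compound 2 to compound 3 (0.03 log units; within the scatter), a result that sits within the scatter and so does not separate the two compounds.

Compound 4, `Cc1nc(N(C)C(=O)NC(=O)c2c(F)cccc2F)sc1C(=O)N/N=C/c1cc(C(F)(F)F)cc(C(F)(F)F)c1`, not yet measured, carries the same change on the core of compound 1: trifluoromethyl in place of hydrogen on an aromatic carbon. The place lines of the two changes agree word for word, so the change is the same change, set on a different core. Among the compounds shown it occurs twice in all, once measured.

The expectation for compound 4 rests on compound 1, whose value is 26.8 ug/mL, with the measured step from compound 2 to compound 3 taken as the guide. Because that step was a 1.1-fold lower number from compound 2 to compound 3 (0.03 log units; within the scatter), a step of about the same size is expected here, a 1.1-fold lower number from compound 1 to compound 4 (0.03 log units; within the scatter), with compound 4 estimated near 25 ug/mL in this assay, between 12 ug/mL and 50 ug/mL.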

Compound 4, half-maximal inhibitory concentration: 12.2 ug/mL
The estimate for compound 4 lay 2.0-fold (0.31 log units) above the measured number; low and high end bracket the measured number.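

On the core of compound 1, trifluoromethyl in place of hydrogen on an aromatic carbon gives a 2.2-fold lower number from compound 1 to compound 4 (0.34 log units; beyond the scatter) in this assay, a modest step, and the comparison with the same change on the other core does not separate the two results: the same change on two cores in this assay, a 1.1-fold lower number (0.03 log units; within the scatter) from compound 2 to compound 3 and a 2.2-fold lower number (0.34 log units; beyond the scatter) from compound 1 to compound 4, 2.0-fold (0.31 log units) apart, within the scatter of two such steps. The change therefore carries from one core to the other without a measurable difference in step size, so the two cores give no ground for treating it as core-dependent in this series. For the compounds shown here, this does not establish a common lowering of the number, as only the step on the core of compound 1 lies beyond the scatter, while compound 2 and compound 3 are not separated; with just two pairs, it also sets no step size for any other core.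

The compounds shown leave open whether another group on the same aromatic carbon, such as a nitrile, an amine or a carboxylic acid, would give a step of similar size on both cores. They also leave open which of the several differences between the core of compound 1 and the core of compound 2 accounts for the gap between those compounds.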